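The source may report more compounds than this note shows. Statements on the series, on what has been measured and on what is new or still open speak of the compounds shown alone.

In an assay on CHO cells for displacement of a labelled ligand from adenosine receptor A3 (Homo sapiens), read by scintillation counting, with a stated time of 120 min, tested at 10 uM (a lower number here means less inhibition, a higher number more inhibition at the concentration tested (going by the name of the read-out)), compound 2 `Nc1scc(CN2CCN(c3ccc(F)c(F)c3)CC2)c1C(=O)c1ccc(Cl)cc1` gives 1%, and compound 1 `Nc1scc(CN2CCN(c3cccc(Cl)c3Cl)CC2)c1C(=O)c1ccc(Cl)cc1` gives 0%; the step of a number 1 percentage points higher from compound 1 to compound 2 (within the scatter) leaves these two within the scatter of each other, so the two numbers are level. Compound 3 `Nc1scc(CN2CCN(c3cc(F)ccc3F)CC2)c1C(=O)c1ccc(Cl)cc1` differs from compound 2 by 2,5-difluorophenyl in place of 3,4-difluorophenyl on an amine nitrogen in a ring. Among the measured compounds shown here, the one measured step bearing on this, from compound 1 to compound 2, also exchanged the group on an amine nitrogen in a ring and moved nothing beyond the scatter, so no shift beyond the scatter is expected for compound 3 either. Compound 3 is therefore estimated at 1%, between -8% and 10%, an expected step of no change at the digits printed from compound 2 to compound 3 (within the scatter).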

Compound 3, a percentage reported as inhibition, at one concentration (the size of the read-out at that concentration, not a potency): 2%
Compound 3: middle estimate off by 1 percentage points, on the low side; measured number inside the range.
By their numbers in this assay, from the lowest: compounds 1, 2 and 3 (each within the scatter of the next).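

In this assay, the same atoms joined differently, 2,5-difluorophenyl in place of 3,4-difluorophenyl on an amine nitrogen in a ring, give a number 1 percentage points higher from compound 2 to compound 3 (within the scatter), so the placing of the two fluorines on this phenyl makes no readable difference here. The exchange for 2,3-dichlorophenyl gives a number 2 percentage points higher from compound 1 to compound 3 (within the scatter), which leaves all three halogenated phenyl groups level. Nothing at hand explains this level reading. On these data alone, whether a benzyl group or a pyridine ring on this nitrogen would give a number beyond the scatter stays open.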